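A Benzyl Triazole Replaces Vinyl on Compound 3

The compounds below may be only part of what the source reports. "The series", "measured", "known", "first", "only" and "open" are said of these compounds alone.

In an ADME assay on HII4E cells (Mus musculus) for cytotoxicity, read by MTT assay, with a stated time of 48 h (a lower number here means a stronger inhibitor, a higher number a weaker inhibitor), compound 1 (`C#CCNC(=O)CO[C@H]1O[C@H](COC(C)=O)C=C(OC(C)=O)C1=O`) gives 282 ug/mL and compound 2 (`CCCCCCCCCCCCNC(=O)CO[C@@H]1O[C@H](COC(C)=O)C=C(OC(C)=O)C1=O`) with its dodecyl chain gives 45 ug/mL in the same test. Compound 3 (`C=CCNC(=O)CO[C@H]1O[C@H](COC(C)=O)C=C(OC(C)=O)/C1=C\C(=O)OCC`) at 352 ug/mL lies within the scatter of compound 1 and beyond the scatter from compound 2, at the weaker end of this small set. Compound 4 (`CCOC(=O)/C=C1\C(OC(C)=O)=C[C@@H](COC(C)=O)O[C@@H]1OCC(=O)NCc1cn(Cc2ccccc2)nn1`) carries 1-benzyl-1H-1,2,3-triazol-4-yl in place of vinyl on a saturated chain carbon bound to an amide-type nitrogen. Within the data shown here, no measured pair shows this change alone. Compound 2 at 45 ug/mL offers the only hint, so a modest drop in the number is expected, possibly within the scatter. The expected change is (a 2.1-fold lower number from compound 3 to compound 4 (0.32 log units; beyond the scatter)). For compound 4 the estimate is 170 ug/mL with a range from 65 ug/mL to 380 ug/mL expected.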

Compound 4, half-maximal inhibitory concentration: 12000 ug/mL
Compound 4: middle estimate off by 71-fold (1.85 log units), on the low side; measured number above the stated range.
By their numbers in this assay, from the lowest: compound 2; then compounds 1 and 3 (each within the scatter of the next); then compound 4.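

In this assay, putting 1-benzyl-1H-1,2,3-triazol-4-yl in place of vinyl on a saturated chain carbon bound to an amide-type nitrogen gives a 34-fold higher number from compound 3 to compound 4 (1.53 log units; beyond the scatter). Among these compounds, this position is therefore far from indifferent to what it carries, and the large step runs toward a weaker inhibitor, which the earlier compounds gave no sign of. Nothing measured here bears on why the number rises so far. From the compounds shown here alone, whether the step follows the benzyl or the triazole ring stays open. So does how an amine or a carboxylic acid would behave at this place.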